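From methyl to isopropyl on compound 2

The compounds below may be only part of what the source reports. "The series", "measured", "known", "first", "only" and "open" are said of these compounds alone.

Measured so far in a functional assay on MIA PaCa-2 cells (Homo sapiens) for inhibition, read by MTT assay, with a stated time of 7 days; on this read-out lower numbers stand for stronger inhibition and higher numbers for weaker inhibition
- compound 1 `CCN(CC)S(=O)(=O)c1ccc(S(=O)(=O)N2CCC[C@@H](C(=O)N(C)C(C)C)C2)cc1` gives 6200 nM
- compound 2 `CCN(CC)S(=O)(=O)c1ccc(S(=O)(=O)N2CCC[C@@H](C(=O)N3CCN(c4nc(C)no4)CC3)C2)cc1` gives 250 nM
- compound 3 `CCN(CC)S(=O)(=O)c1ccc(S(=O)(=O)N2CCC[C@@H](C(=O)NC3CN(S(C)(=O)=O)C3)C2)cc1` gives 2500 nM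

Compound 2 holds the lowest number of the three, with 250 nM in this assay as its value. Compound 4 `CCN(CC)S(=O)(=O)c1ccc(S(=O)(=O)N2CCC[C@@H](C(=O)N3CCN(c4nc(C(C)C)no4)CC3)C2)cc1` differs from it in one place. The change is isopropyl in place of methyl on an aromatic carbon and puts isopropyl in place of methyl on an aromatic carbon.

The measured steps all swap whole groups on a carbonyl carbon. The large one is a 25-fold lower number from compound 1 to compound 2 (1.39 log units; beyond the scatter) and a modest one is a 2.5-fold lower number from compound 1 to compound 3 (0.39 log units; beyond the scatter) while the third, also modest, is a 10-fold higher number from compound 2 to compound 3 (1.00 log units; beyond the scatter) as shown. They show that this part of the series can move the number widely, but none of them touches the methyl, so they bear on the new change only indirectly. In this assay no step beyond the scatter is therefore expected, and no firm direction. The estimated step is a 1.3-fold lower number from compound 2 to compound 4 (0.10 log units; within the scatter) at most in size. The estimate for compound 4 is 200 nM as the expected value (70 nM to 550 nM).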

Compound 4, half-maximal inhibitory concentration: 50 nM
For compound 4 the middle estimate is 4.0-fold (0.60 log units) above the measured one; measured number below the stated range.
By their numbers in this assay, from the lowest: compound 4; then compound 2; then compound 3; then compound 1.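

In this assay, isopropyl in place of methyl on the aromatic carbon gives a 5.0-fold lower number from compound 2 to compound 4 (0.70 log units; beyond the scatter) and so shows that the small group on this five-membered ring can itself move the number, which the earlier swaps of whole groups on the carbonyl carbon could not show. The change adds only carbon, with no ring, hydrogen-bond donor, hydrogen-bond acceptor or net charge entering, and the step still lies beyond the scatter. Nothing measured here accounts for the size or direction of this step.

The compounds shown leave open whether the number would keep falling with a tert-butyl group or a longer chain such as n-butyl at this carbon, or whether a cyclopropyl or phenyl ring would do the same. They also leave open what a hydrogen or an amine would do there.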